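A few compounds are considered here, and "the series" means these few. Any claim that something is new, unique, unknown or untested is made for them only; others in the source may bear on it.

Values measured in an in vivo ADME assay on the whole organism (Canis lupus familiaris) for metabolic stability; a higher number here means that the compound lasts longer, a lower number that the compound disappears faster:

- Compound 1 `O=C(O)C[C@H](CCCCCCc1ccc2c(n1)NCCC2)c1cncnc1`: 6.4 h
- Compound 2 `O=C(O)C[C@H](CCCCCCc1ccc2c(n1)NCCC2)c1cnc2ccccc2c1`: 5 h
- Compound 3 `O=C(O)C[C@H](CCCCCCc1ccc2c(n1)NCCC2)c1ccc2c(c1)OCC2`: 5.8 h

Compound 2, at 5 h, cannot be told apart from the other two compounds, since its value lies within the scatter of both. The next compound, compound 4 `COc1ccc([C@@H](CCCCCCc2ccc3c(n2)NCCC3)CC(=O)O)cn1`, carries 6-methoxypyridin-3-yl in place of quinolin-3-yl on a saturated chain carbon bound to two saturated chain carbons.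

Three measured steps exchange the group at this same place. They are a 1.3-fold lower number from compound 1 to compound 2 (0.11 log units; within the scatter), a 1.1-fold lower number from compound 1 to compound 3 (0.04 log units; within the scatter) and a 1.2-fold higher number from compound 2 to compound 3 (0.06 log units; within the scatter), and all three lie within the scatter. For the measured compounds named here, none of the measured compounds carries the entering group, so this evidence is indirect. Even so, no step beyond the scatter is expected in this assay, and no direction can be favoured with confidence. The expected change is a 1.1-fold higher number from compound 2 to compound 4 (0.04 log units; within the scatter), which is an estimate within the scatter. Compound 4 is estimated at 5.5 h, with an expected range from 3 h to 9.5 h.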

Compound 4, half-life: 9.5 h
For compound 4 the middle estimate is 1.7-fold (0.24 log units) below the measured one; measured number inside the range.
By their numbers in this assay, from the lowest: compounds 2, 3, 1 and 4 (each within the scatter of the next).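

In this assay the entry of 6-methoxypyridin-3-yl on this saturated chain carbon gives a 1.9-fold higher number from compound 2 to compound 4 (0.28 log units; within the scatter) and a 1.6-fold higher number from compound 3 to compound 4 (0.21 log units; within the scatter) and a 1.5-fold higher number from compound 1 to compound 4 (0.17 log units; within the scatter) so a fourth group, and the first here with a methoxy substituent, also produces no step beyond the scatter. The position therefore accepts a single ring carrying this substituent as well as the bare single ring of compound 1 and the two-ring groups of compound 2 and compound 3, with no measurable difference in this read-out. Nothing available explains the result, and no separate measurement bears on this change.

What the methoxy group itself contributes stays open, since the compounds shown do not include the unsubstituted pyridin-3-yl group. Going by these compounds, it is also open whether a non-aromatic group at this place, such as a cyclohexyl ring or an amine, would give a step beyond the scatter.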